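This account rests on a few compounds, and the source may have more. Where it says the series, first, only, none or still open, it means among the compounds named here.

The measured compounds:

Compound 1 `O=C1O/C(=C\Cn2cc(-c3ccc(Br)cc3)nn2)C(OCc2ccccc2)=C1OCc1ccccc1` gives in an ADME assay on HFF cells (Homo sapiens) for cytotoxicity, read by MTT assay, with a stated time of 72 h (on this read-out higher numbers stand for weaker inhibition and lower numbers for stronger inhibition), a value of > 100000 nM, which is a limit of the assay and not a number.
Compound 2 `Cc1ccc(-c2cn(C/C=C3\OC(=O)C(OCc4ccccc4)=C3OCc3ccccc3)nn2)cc1` gives in this assay a value of > 100000 nM, again a limit of the assay.
Compound 3 `CCCCCc1ccc(-c2cn(C/C=C3\OC(=O)C(OCc4ccccc4)=C3OCc3ccccc3)nn2)cc1` gives in this assay a value of > 100000 nM, again a limit of the assay.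

Compound 3 therefore stands at a limit rather than at a number, and it cannot be placed in any order against the other two, since all three values sit together at the same limit (the limit of > 100000 nM in this assay, at which 3 of the 3 values shown sit). The steps a step that the two limits leave unreadable from compound 1 to compound 2, a step that the two limits leave unreadable from compound 1 to compound 3 and a step that the two limits leave unreadable from compound 2 to compound 3 are for that reason of unreadable size.

Compound 4 `COc1ccc(-c2cn(C/C=C3\OC(=O)C(OCc4ccccc4)=C3OCc3ccccc3)nn2)cc1` differs from compound 3 in one place: methoxy in place of pentyl on an aromatic carbon. The three measured steps all bear on a change of the same kind, a swap of the group on that aromatic carbon, and none of them could be read. No readable step is expected in this assay; the step that the limit leaves unreadable from compound 3 to compound 4 is expected to be nothing beyond the scatter. Compound 4 is estimated in this assay at 150000 nM, with a range from 50000 nM to 500000 nM, and most likely the assay will again report only a limit.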

Compound 4, half-maximal inhibitory concentration: > 100000 nM
Compound 4 ended at the assay's limit (the forecaster's own chance of this, stated with the estimate: 90%); the middle value is on the limit's open side.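

Among these compounds, compound 4 gives only a limit in this assay, as do compound 1, compound 2 and compound 3, so no step among them can be read: the limit of > 100000 nM in this assay, at which 4 of the 4 values shown sit. The compounds shown leave open whether the group on that aromatic carbon changes cytotoxicity at all in this assay.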